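Amine swap on the dichlorobenzamide series

This account rests on a few compounds, and the source may have more. Where it says the series, first, only, none or still open, it means among the compounds named here.

Measured so far:
compound 1 `CCN1CCN(c2cc(C)c3cc(NC(=O)c4ccccc4F)ccc3n2)CC1` 38100 nM
compound 2 `CCN(CC)CCNc1cc(C)c2cc(NC(=O)c3ccc(Cl)c(Cl)c3)ccc2n1` 3710 nM
compound 3 `CCN1CCN(c2cc(C)c3cc(NC(=O)c4ccccc4OC)ccc3n2)CC1` 15700 nM

Three compounds share one core and are read in a functional assay on SK-BR-3 cells (Homo sapiens) for antiproliferative activity, read by MTT assay, with a stated time of 72 h; on this read-out lower numbers stand for stronger inhibition and higher numbers for weaker inhibition. Compound 2 stands lowest of the three numbers, ahead of compound 3 by a margin beyond the scatter and of compound 1 by a larger one. Within the data shown here, the only single-point step measured, a 2.4-fold lower number from compound 1 to compound 3 (0.39 log units; beyond the scatter), concerns the amide and not the amine side; it does not bear on the change at hand.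

Compound 4 `Cc1cc(N2CCN(C)CC2)nc2ccc(NC(=O)c3ccc(Cl)c(Cl)c3)cc12` keeps the dichlorobenzamide of compound 2 and differs only in 4-methylpiperazin-1-yl in place of (2-(diethylamino)ethyl)amino on an aromatic carbon. Among the measured compounds shown here, no measured pair isolates this change, so no step beyond the scatter is expected, with a slight lean toward a higher number; the expected step is a 1.5-fold higher number from compound 2 to compound 4 (0.17 log units; within the scatter). Compound 4 is estimated at 5500 nM, within 1800 nM to 17000 nM.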

Compound 4, half-maximal inhibitory concentration: 6320 nM
For compound 4 the middle estimate is 1.1-fold (0.06 log units) below the measured one; the range from low to high includes it.
By their numbers in this assay, from the lowest: compounds 2 and 4 (each within the scatter of the next); then compound 3; then compound 1.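

In this assay, the amine swap on the aromatic carbon next to the ring nitrogen gives a 1.7-fold higher number from compound 2 to compound 4 (0.23 log units; within the scatter). With the dichlorobenzamide held fixed, this position therefore accepts the ring of 4-methylpiperazin-1-yl in place of the open (2-(diethylamino)ethyl)amino chain, and the loss of its hydrogen-bond donor, without a step beyond the scatter. No measurement at hand explains this outcome.

Open, from the compounds shown here alone, is whether morpholin-4-yl or a longer aminoalkyl chain at this carbon would give a step beyond the scatter. Also open, going by these compounds, is whether the swap reads the same with the fluoro or methoxy benzamides.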